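Sulfonyl substituent series: sulfonamide nitrogen replaced by aryl sulfone

The source may report more compounds than this note shows. Statements on the series, on what has been measured and on what is new or still open speak of the compounds shown alone.

In an assay on isolated protein for activation of Nicotinamide phosphoribosyltransferase (Homo sapiens) (on this read-out higher numbers stand for an effect only at larger amounts of compound and lower numbers for an effect already at smaller amounts), compound 1 `CN(Cc1ccccc1)S(=O)(=O)c1ccc(NC(=O)NCc2ccncc2)cc1` gives 23 nM, compound 2 `CNS(=O)(=O)c1ccc(NC(=O)NCc2ccncc2)cc1` gives 3230 nM, and compound 3 `CCN(C1CCCC1)S(=O)(=O)c1ccc(NC(=O)NCc2ccncc2)cc1` gives 60 nM. Compound 3 holds the second highest of the three numbers: compound 1 is nearest, a 2.6-fold higher number from compound 1 to compound 3 (0.42 log units; beyond the scatter), and compound 2 is furthest, a 54-fold lower number from compound 2 to compound 3 (1.73 log units; beyond the scatter).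

Compound 4 `O=C(NCc1ccncc1)Nc1ccc(S(=O)(=O)c2cccc(Cl)c2)cc1` is not yet measured. The change is 3-chlorophenyl in place of cyclopentyl(ethyl)amino on a sulfonyl sulfur. The measured steps all keep the sulfonamide nitrogen and vary only what sits on it, so none of them covers the present change directly. They show that removing a large substituent from that nitrogen costs a great deal, a 140-fold higher number from compound 1 to compound 2 (2.15 log units; beyond the scatter), while swapping one large substituent for another costs little, a 2.6-fold higher number from compound 1 to compound 3 (0.42 log units; beyond the scatter). Since compound 4 keeps a sizeable group on the sulfonyl sulfur, a step no larger than the modest one is expected, no change at the digits printed from compound 3 to compound 4 (within the scatter). Among the compounds with values here, compound 4 is therefore estimated at 60 nM in this assay, within a range of 12 nM to 300 nM, the width reflecting that no measured pair tests this kind of replacement.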

Compound 4, half-maximal effective concentration: 69 nM
Compound 4: the middle estimate sits 1.2-fold (0.06 log units) below what was measured; the measured number falls inside the stated range.
By their numbers in this assay, from the lowest: compound 1; then compounds 3 and 4 (each within the scatter of the next); then compound 2.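

In this assay the nitrogen on the sulfonyl sulfur is not required: 3-chlorophenyl in place of cyclopentyl(ethyl)amino gives a 1.2-fold higher number from compound 3 to compound 4 (0.06 log units; within the scatter) and so leaves the number unchanged within the scatter. The same aryl group, set against methylamino, gives a 47-fold lower number from compound 2 to compound 4 (1.67 log units; beyond the scatter) and thus recovers nearly all of what that compound lacks, while against benzyl(methyl)amino it gives a 3.0-fold higher number from compound 1 to compound 4 (0.48 log units; beyond the scatter) and so does not reach the lowest number in the set. No measurement at hand explains these steps.

Going by these compounds, what the chlorine contributes remains open, since a plain phenyl or a fluorophenyl on the sulfonyl sulfur would separate it from the ring. A cyclopentyl or benzyl group attached directly to the sulfur would show whether the aromatic ring itself matters once the nitrogen is gone.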